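The source may hold more compounds than are shown below. What is called first, only, known or untested is meant among the compounds shown, and "the series" means these compounds.

Working notes on a series sharing one core, read in a functional assay on A549 cells (Homo sapiens) for cytotoxicity, read by MTT assay, with a stated time of 72 h; on this read-out lower numbers stand for stronger inhibition and higher numbers for weaker inhibition. Compound 1 (`O=C(CN1CCN(c2nnc(Cc3ccccc3)c3ccccc23)CC1)Nc1c(F)cccc1F`) gives 84500 nM, and compound 2 (`COc1ccc(NC(=O)CN2CCN(c3nnc(Cc4ccccc4)c4ccccc34)CC2)cc1OC`) is reported as "not active" (no number reported). Compound 3 (`O=C(CN1CCN(c2nnc(Cc3ccccc3)c3ccccc23)CC1)Nc1ccc(Br)cc1`) gives 2000 nM, the lower of the two numbers available. Compound 4 (`O=C(CN1CCN(c2nnc(Cc3ccccc3)c3ccccc23)CC1)Nc1cc(C(F)(F)F)ccc1Cl`) differs from it on the amide-type nitrogen: 2-chloro-5-(trifluoromethyl)phenyl in place of 4-bromophenyl on an amide-type nitrogen. Among the compounds with values here, the one measured step bearing on this is large: a 42-fold lower number from compound 1 to compound 3 (1.63 log units; beyond the scatter), with 4-bromophenyl replacing 2,6-difluorophenyl at that same place. Within the data shown here, compound 4 gives up that 4-bromophenyl, and no measured compound carries its new group, so a moderate move towards a higher number in this assay is expected, with wide uncertainty. The expected change is a 3.5-fold higher number from compound 3 to compound 4 (0.54 log units; beyond the scatter). Compound 4 is estimated at 7000 nM, with an expected range of 1500 nM to 40000 nM.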

Compound 4, half-maximal inhibitory concentration: 89000 nM
Beside the measured number, compound 4's estimate is 13-fold (1.10 log units) below it; the measured number lies above the stated range.
By their numbers in this assay, from the lowest: compound 3; then compounds 1 and 4 (each within the scatter of the next).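

At the amide-type nitrogen, this assay shows a 45-fold higher number from compound 3 to compound 4 (1.65 log units; beyond the scatter), so a second replacement of 4-bromophenyl now gives a much higher number. The two replacements do not separate, with a 1.1-fold higher number from compound 1 to compound 4 (0.02 log units; within the scatter), and among the compounds with numbers only 4-bromophenyl stands apart at this place. Nothing measured here accounts for the size of these steps.

Still open, going by these compounds, is whether the lower number depends on the bromine itself, which a 4-chlorophenyl or an unsubstituted phenyl on the same nitrogen would test.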